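Swapping an Ether Tail for a Urea Tail: Cytotoxicity Outlook

The compounds below may be only part of what the source reports. "The series", "measured", "known", "first", "only" and "open" are said of these compounds alone.

Measured so far:
Compound 1, `Cc1nc(NC(C)(C)C)nc(N[C@@H]2C[C@H](CO)[C@@H](O)[C@H]2O)c1-c1nc2ccccc2s1`, in an ADME assay on cells (Homo sapiens) for cytotoxicity, read by polymerase chain reaction, with a stated time of 3 days (on this read-out lower numbers stand for higher toxicity in this test and higher numbers for lower toxicity in this test), gives 12000 nM.
Compound 2, `CCOCCNc1nc(C)c(-c2nc3ccccc3s2)c(N[C@@H]2C[C@H](CO)[C@@H](O)[C@H]2O)n1`, in this assay gives 18000 nM.

Of these two numbers, compound 2 holds the higher one, but its nearest neighbour is compound 1, and the step of a 1.5-fold higher number from compound 1 to compound 2 (0.18 log units; within the scatter) lies within the scatter, so the two are not distinguishable on this evidence. That step exchanged one side chain on the aromatic ring nitrogen for another and left the read-out essentially unchanged.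

Compound 3, `Cc1nc(NCCNC(=O)NC(C)(C)C)nc(N[C@@H]2C[C@H](CO)[C@@H](O)[C@H]2O)c1-c1nc2ccccc2s1`, carries a further alteration of the same chain: ((tert-butyl)carbamoyl)amino in place of ethoxy on a saturated chain carbon, two bonds along the chain from a nitrogen on an aromatic ring. Among the measured compounds shown here, the only measured step that bears on it is the one from compound 1 to compound 2, which was within the scatter. With one such comparison, and that one flat, there is no basis for expecting a shift in this assay beyond the scatter in either direction; the group entering is larger and brings hydrogen-bond donors, but nothing measured here shows what that does. Compound 3 is therefore expected to land close to compound 2, with the estimated step of no change at the digits printed from compound 2 to compound 3 (within the scatter) amounting to no real change. The estimate for compound 3 is 18000 nM, within a range from 8000 nM to 40000 nM.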

Compound 3, half-maximal cytotoxic concentration: > 25000 nM
Compound 3 ended at the assay's limit (the forecaster's own chance of this, stated with the estimate: 20%); middle value at least 1.3-fold (0.14 log units) from the limit.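

Compound 3 gives no exact number here, only a limit of this assay: the limit of > 25000 nM in this assay, at which 1 of the 3 values shown sits. Read against the ether chain, the step is an at least 1.3-fold higher number from compound 2 to compound 3 (0.14 log units; that floor lies within the scatter), so ((tert-butyl)carbamoyl)amino in place of ethoxy on this saturated chain carbon cannot yet be told apart from no change, although the true difference could be larger than this floor. Read against the plain tert-butyl group, the step is an at least 2.0-fold higher number from compound 1 to compound 3 (0.31 log units; beyond the scatter), which makes 2-(((tert-butyl)carbamoyl)amino)ethyl the first replacement shown on this aromatic ring nitrogen to clear the scatter, pointing towards lower toxicity in this test, whereas 2-ethoxyethyl did not clear it.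

From the compounds shown here alone, how far the true value of compound 3 lies past the limit remains unknown, so the full size of both steps stays open. Also open, going by these compounds, is which part of the new chain matters, and whether a chain ending in a simple amine or a carboxylic acid, or a longer chain carrying the same ((tert-butyl)carbamoyl)amino group, would shift the read-out in either direction.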